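Lengthening the sulfur-bound chain in a cytotoxicity series

The source may report more compounds than this note shows. Statements on the series, on what has been measured and on what is new or still open speak of the compounds shown alone.

Of the compounds shown here, two on a shared core have been measured so far: compound 1 `CCCCNc1nc(SCC)nc2ncccc12` and compound 2 `CCCCNc1nc(SC(C)C)nc2ncccc12`, which differ only in the group on the sulfur. In a functional assay on T-24 cells (Homo sapiens) for cytotoxicity, read by neutral red uptake, with a stated time of 72 h (on this read-out lower numbers stand for stronger inhibition and higher numbers for weaker inhibition), compound 1 gives 20900 nM, and in this assay compound 2 gives 12300 nM. The move a 1.7-fold lower number from compound 1 to compound 2 (0.23 log units; within the scatter) stays within the scatter, so the two numbers cannot be told apart with confidence. Compound 2 stands at its own value, with compound 1 lying within the scatter of it.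

Compound 3 `CCCCNc1nc(SCCCC)nc2ncccc12` has not been measured in this assay. It differs from compound 2 by butyl in place of isopropyl on a sulfur. Going by the values given here, the only measured step that bears on this place is the one from compound 1 to compound 2, and that step, a 1.7-fold lower number from compound 1 to compound 2 (0.23 log units; within the scatter), was within the scatter. Nothing measured here shows that a change of the sulfur-bound chain moves the number in this assay beyond the scatter, so no step beyond it is expected for compound 3. Compound 3 is therefore estimated at 12000 nM, with a range from 5000 nM to 30000 nM. The expected step from compound 2 to compound 3 is a 1.0-fold lower number from compound 2 to compound 3 (0.01 log units; within the scatter).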

Compound 3, half-maximal inhibitory concentration: 10600 nM
Beside the measured number, compound 3's estimate is 1.1-fold (0.05 log units) above it; the measured number falls inside the stated range.
By their numbers in this assay, from the lowest: compounds 3, 2 and 1 (each within the scatter of the next).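

In this assay the position on the sulfur now has a second and a third comparison: butyl in place of isopropyl gives a 1.2-fold lower number from compound 2 to compound 3 (0.06 log units; within the scatter) and, on the straight chain, ethyl in place of hydrogen two bonds along from the sulfur gives a 2.0-fold lower number from compound 1 to compound 3 (0.29 log units; within the scatter). Both steps lie within the scatter, so ethyl, isopropyl and butyl on this sulfur cannot be told apart, whether the chain is branched or straight, and this holds for all three compounds shown. Nothing available here accounts for how close these numbers lie.

The compounds shown leave open whether any group on this sulfur can move the number beyond the scatter, for instance a much longer chain such as octyl, a benzyl group, or a chain ending in an amine or a carboxylic acid. They also leave open how the butylamino group elsewhere on the shared core bears on the number, since it stays the same in all three compounds.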